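Removing a Methoxycarbonyl Group: Expected Effect on Solubility

The source may report more compounds than this note shows. Statements on the series, on what has been measured and on what is new or still open speak of the compounds shown alone.

Compound 1 `COC(=O)c1cccc(NC(=O)c2cc3cc([N+](=O)[O-])ccc3o2)c1`: 25 ug/mL
Compound 2 `CC(C)(C)OC(=O)NCc1ccccc1NC(=O)c1ccc(-c2ccccc2)cc1`: < 5 ug/mL
Compound 3 `NC(=O)c1ccccc1NC(=O)c1ccc2ccccc2n1`: 10 ug/mL

Of the compounds shown here, three have been measured in a physicochemical assay for solubility; on this read-out higher numbers stand for higher solubility and lower numbers for lower solubility. Compound 1 gives 25 ug/mL and stands highest of the two numbers available. Compound 3 gives 10 ug/mL, a value that lies beyond the usual scatter from the value of compound 1. For compound 2 the read-out is the limit of < 5 ug/mL in this assay, at which 1 of the 3 values shown sits, a limit of the assay rather than a number. Within the data shown here, none of these three compounds differs from another in a single place, so no measured step connects them, and the numbers can only be placed side by side.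

Compound 4 `O=C(Nc1ccccc1)c1cc2cc([N+](=O)[O-])ccc2o1` has not yet been measured. It differs from compound 1 by hydrogen in place of methoxycarbonyl on an aromatic carbon. Among the measured compounds shown here, no measured pair shows what such a change does in this assay, so the expectation rests on the value of compound 1 alone. The step is expected to be small, within or only just beyond the usual scatter, with no clear direction; the estimated step is a 1.3-fold lower number from compound 1 to compound 4 (0.10 log units; within the scatter). Compound 4 is therefore expected to give about 20 ug/mL, with a range from 6 ug/mL to 60 ug/mL.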

Compound 4, solubility: 25 ug/mL
For compound 4 the middle estimate is 1.3-fold (0.10 log units) below the measured one; low and high end bracket the measured number.
By their numbers in this assay, from the lowest: compound 3; then compounds 1 and 4 (each within the scatter of the next). At a limit, below all of these: compound 2.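

In this assay, among these compounds, the exchange of methoxycarbonyl for hydrogen gives the first step that can be read between two compounds differing in one place: no change at the digits printed from compound 1 to compound 4 (within the scatter). So on this aromatic carbon, meta to a large group, the whole methoxycarbonyl group can give way to a single hydrogen atom while the read-out stays within the usual scatter, something the earlier compounds could not show, as they could only be placed side by side. Nothing among the measurements at hand offers a reason for this outcome.

A single step at a single position cannot say whether other groups on the same carbon, such as an amine or a carboxylic acid, would leave the number where compound 1 and compound 4 have it. Going by these compounds, it also remains open whether the same exchange of methoxycarbonyl for hydrogen would read the same way at another place on this ring, or on a core other than the one shared by these two compounds.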